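This account rests on a few compounds, and the source may have more. Where it says the series, first, only, none or still open, it means among the compounds named here.

The three compounds measured so far, each in a functional assay on SMMC-7721 cells (Homo sapiens) for antiproliferative activity, read by MTT assay, with a stated time of 48 h; on this read-out lower numbers stand for stronger inhibition and higher numbers for weaker inhibition:

Compound 1 `Cn1cc(C2=C(c3n[nH]c4ncccc34)C(=O)NC2=O)c2ccccc21` gives > 100000 nM, a limit of the assay.
Compound 2 `Cn1cc(C2=C(c3nn(CCCn4ccnc4)c4ncccc34)C(=O)NC2=O)c2ccccc21` gives > 100000 nM, also a limit.
Compound 3 `Cn1cc(C2=C(c3nn(CCCn4cccc4)c4ncccc34)C(=O)NC2=O)c2ccccc21` gives > 100000 nM, again a limit.

Compound 1 thus stands not at a number but at the limit of the assay, and it shares that limit with both other measured compounds: the limit of > 100000 nM in this assay, at which 3 of the 3 values shown sit. Going by the values given here, the steps that bear on the change to be judged are the step from compound 1 to compound 2, a step that the two limits leave unreadable from compound 1 to compound 2, and the step from compound 1 to compound 3, a step that the two limits leave unreadable from compound 1 to compound 3; the step from compound 2 to compound 3, a step that the two limits leave unreadable from compound 2 to compound 3, is of the same kind. None of them can be read for size or direction.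

Compound 4 `Cn1cc(C2=C(c3nn(CCCN4CCCCC4)c4ncccc34)C(=O)NC2=O)c2ccccc21` differs from compound 1 by 3-(piperidin-1-yl)propyl in place of hydrogen on an aromatic nitrogen. The two groups already placed on that aromatic nitrogen, 3-(1H-imidazol-1-yl)propyl and 3-(1H-pyrrol-1-yl)propyl, both left the read-out at the limit. Compound 4 is therefore expected to give 100000 nM, within 20000 nM to 300000 nM, most probably again only as a limit. The step from compound 1 to compound 4 that this estimate means, a number no higher from compound 1 to compound 4 (the limit leaves the size open), is expected to be no readable step at all.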

Compound 4, half-maximal inhibitory concentration: 7670 nM
Beside the measured number, compound 4's estimate is 13-fold (1.12 log units) above it; measured number outside the range, below it.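

In this assay, the aromatic nitrogen of the shared core proves able to carry a group that moves the read-out: 3-(piperidin-1-yl)propyl in place of hydrogen gives an at least 13-fold lower number from compound 1 to compound 4 (1.11 log units; beyond the scatter). With the propyl chain unchanged, piperidin-1-yl in place of 1H-pyrrol-1-yl gives an at least 13-fold lower number from compound 3 to compound 4 (1.11 log units; beyond the scatter), and in place of 1H-imidazol-1-yl it gives an at least 13-fold lower number from compound 2 to compound 4 (1.11 log units; beyond the scatter), so among these compounds the ring at the end of the chain decides the outcome, not the chain alone. Compound 1, compound 2 and compound 3 each remain at a limit of the assay, and the steps among them cannot be read: the limit of > 100000 nM in this assay, at which 3 of the 4 values shown sit.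

The compounds shown leave open whether another amine at the chain end, such as morpholin-4-yl or dimethylamino, would act as piperidin-1-yl does. They also leave open whether piperidin-1-yl would keep this effect on an ethyl or butyl chain.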